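Ring-nitrogen chain extension on two aryl variants

This account rests on a few compounds, and the source may have more. Where it says the series, first, only, none or still open, it means among the compounds named here.

Measured so far:
compound 1, `CO[C@@]12CCN(C)C[C@H]1[C@H](c1ccc(Cl)cc1Cl)C(C#N)=C(N)O2`, giving 14900 nM
compound 2, `CCCN1CC[C@@]2(OC)OC(N)=C(C#N)[C@@H](c3ccc(Cl)cc3Cl)[C@@H]2C1`, giving 35500 nM
compound 3, `CO[C@@]12CCN(C)C[C@H]1[C@H](c1ccc(F)cc1)C(C#N)=C(N)O2`, giving 19400 nM

All three numbers come from a functional assay on trachea (Cavia porcellus); on this read-out lower numbers stand for stronger inhibition and higher numbers for weaker inhibition. Compound 4, `CCCN1CC[C@@]2(OC)OC(N)=C(C#N)[C@@H](c3ccc(F)cc3)[C@@H]2C1`, is not yet measured there. The two cores differ by 4-fluorophenyl in place of 2,4-dichlorophenyl on a saturated ring carbon, and that swap gave a 1.3-fold higher number from compound 1 to compound 3 (0.11 log units; within the scatter). The chain change is ethyl in place of hydrogen on a saturated chain carbon bound to an amine nitrogen in a ring, which produced a 2.4-fold higher number from compound 1 to compound 2 (0.38 log units; beyond the scatter). The same change, (ethyl in place of hydrogen on a saturated chain carbon bound to an amine nitrogen in a ring), at the same place, carries compound 3 to compound 4. Because the step of a 2.4-fold higher number from compound 1 to compound 2 (0.38 log units; beyond the scatter) on the core of compound 1 was modest, the step from compound 3 to compound 4 is expected to be of similar size, a 2.3-fold higher number from compound 3 to compound 4 (0.37 log units; beyond the scatter). Compound 4 is therefore estimated at 45000 nM in this assay, expected to fall between 20000 nM and 100000 nM.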

Compound 4, half-maximal inhibitory concentration: 29600 nM
Compound 4: middle estimate off by 1.5-fold (0.18 log units), on the high side, and the stated range covers the measured number.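

In this assay, the methyl to propyl change gives a 1.5-fold higher number from compound 3 to compound 4 (0.18 log units; within the scatter), and its size agrees on the two cores: the same change on two cores in this assay, a 2.4-fold higher number (0.38 log units; beyond the scatter) from compound 1 to compound 2 and a 1.5-fold higher number (0.18 log units; within the scatter) from compound 3 to compound 4, 1.6-fold (0.19 log units) apart, within the scatter of two such steps. The swap of 2,4-dichlorophenyl for 4-fluorophenyl gives a 1.2-fold lower number from compound 2 to compound 4 (0.08 log units; within the scatter), and it also carries over between the two chain lengths: the same change on two cores in this assay, a 1.3-fold higher number (0.11 log units; within the scatter) from compound 1 to compound 3 and a 1.2-fold lower number (0.08 log units; within the scatter) from compound 2 to compound 4, 1.6-fold (0.19 log units) apart, within the scatter of two such steps. This shows that both changes transfer without a detectable departure across these four compounds, but two cores cannot establish transfer across the wider series, and the chain step lies beyond the scatter on one core and within it on the other.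

Open, going by these compounds, is whether a butyl chain or a benzyl group on the amine nitrogen in a ring would follow the same trend. Also open, on these data alone, is whether an aryl group carrying a methoxy substituent would behave like the two aryl groups seen here.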